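Phosphorus configuration inverted on a thiazolyl ester prodrug

A few compounds are considered here, and "the series" means these few. Any claim that something is new, unique, unknown or untested is made for them only; others in the source may bear on it.

Compound 2 `COC(=O)CCNC(=O)[C@@H]1O[P@](=O)(OCOC(=O)c2scnc2C(C)(C)C)OCC1(C)C` gives 0.44 h in an ADME assay on blood (Homo sapiens) for pharmacokinetics (a higher number here means that the compound lasts longer, a lower number that the compound disappears faster), the highest of the two numbers in hand. Compound 1 `COC(=O)CCNC(=O)[C@@H]1O[P@](=O)(OCOC(=O)c2ocnc2C)OCC1(C)C` gives 0.27 h in this assay; the step of a 1.6-fold higher number from compound 1 to compound 2 (0.21 log units; within the scatter) concerns the acyl group on the carbonyl carbon. For compound 3 `CCc1cc(C(=O)OCO[P@]2(=O)OCC(C)(C)[C@H](C(=O)NCCC(=O)OC)O2)n(C)n1` only a limit is known, < 0.16 h in this assay, (the limit of < 0.16 h in this assay, at which 1 of the 3 values shown sits). Going by the values given here, the step of an at least 2.7-fold lower number from compound 2 to compound 3 (0.43 log units; beyond the scatter) and the step of an at least 1.6-fold lower number from compound 1 to compound 3 (0.22 log units; that floor lies within the scatter) again alter only that acyl group.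

Compound 4 `COC(=O)CCNC(=O)[C@@H]1O[P@@](=O)(OCOC(=O)c2scnc2C(C)(C)C)OCC1(C)C` differs from compound 2 in another way: the two compounds have the same atoms and bonds and differ only in configuration as drawn: 1 of 2 stereo elements differ; a stereocentre at a phosphorus is drawn R in compound 2 and S in compound 4. Among the compounds with values here, no measured step changes a configuration; every step known alters the heteroaryl ester instead, so none of them bears on this change, and its size is left open by the data. Compound 4 is therefore expected to remain near compound 2, with a step of no change at the digits printed from compound 2 to compound 4 (within the scatter) in this assay that is estimated to stay within the scatter. Compound 4 is estimated at 0.44 h in this assay, with a range from 0.18 h to 1.1 h.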

Compound 4, half-life: > 1 h
Compound 4 ended at the assay's limit (the forecaster's own chance of this, stated with the estimate: 15%); middle value at least 2.2-fold (0.35 log units) from the limit.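

Going by these compounds alone, the phosphorus stereocentre matters in this assay, a point the earlier compounds could not show, as they varied only the heteroaryl ester. The step of an at least 2.2-fold higher number from compound 2 to compound 4 (0.35 log units; beyond the scatter) keeps the 4-(tert-butyl)-1,3-thiazol-5-yl ester unchanged and, with nothing entering or leaving, can be ascribed to configuration alone: the fact that compounds 2 and 4 differ only in the configuration as drawn. Compound 4 sits at a limit of the assay and not at a number, which leaves the full size of this step unknown: the limit of > 1 h in this assay, at which 1 of the 4 values shown sits.

The compounds shown leave open whether inverting phosphorus has a similar effect with the 4-methyl-1,3-oxazol-5-yl or 3-ethyl-1-methyl-1H-pyrazol-5-yl ester, as this is the only pair compared. They also leave open whether it would hold with a carboxylic acid in place of the methyl ester on the amide side chain.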